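Swapping One Ring Group in an Antiproliferative Series

This account rests on a few compounds, and the source may have more. Where it says the series, first, only, none or still open, it means among the compounds named here.

Compound 1 `CC(O)(CSc1ccc(S(F)(F)(F)(F)F)cc1)C(=O)Nc1ccc(C#N)c(C(F)(F)F)c1` gives 16900 nM
Compound 2 `CC(O)(CSc1ccc(S(F)(F)(F)(F)F)cc1)C(=O)Nc1ccc(S(F)(F)(F)(F)F)cc1` gives 18300 nM
Compound 3 `CC(O)(COc1ccc(S(F)(F)(F)(F)F)cc1)C(=O)Nc1ccc(S(F)(F)(F)(F)F)cc1` gives 9800 nM

These numbers come from a functional assay on LNCaP cells (Homo sapiens) for antiproliferative activity, read by propidium iodide staining, with a stated time of 96 h (a lower number here means a stronger inhibitor, a higher number a weaker inhibitor), and compound 3 at 9800 nM sits within the usual scatter of both other compounds, so the three cannot be ranked. Compound 4 `CC(O)(COc1ccc(C#N)cc1)C(=O)Nc1ccc(S(F)(F)(F)(F)F)cc1` differs from compound 3 by a group of 2 heavy atoms (1 carbon, 1 nitrogen; no ring) in place of a group of 6 heavy atoms (5 fluorine, 1 sulfur; no ring), on an aromatic carbon at one place, with cyano on an aromatic carbon, para to a large group. Within the data shown here, no measured pair shows this change alone, so any forecast is rough. A modest rise in this assay is expected, the estimated step running a 1.4-fold higher number from compound 3 to compound 4 (0.15 log units; within the scatter) and possibly staying within the scatter. Compound 4 is expected at 14000 nM with an estimated range from 5000 nM to 40000 nM as its likely span.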

Compound 4, half-maximal inhibitory concentration: 100000 nM
For compound 4 the middle estimate is 7.1-fold (0.85 log units) below the measured one; the whole stated range lies below it.
By their numbers in this assay, from the lowest: compounds 3, 1 and 2 (each within the scatter of the next); then compound 4.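

On the aromatic carbon para to a large group, the choice of group clearly matters in this assay: cyano in place of the group of 5 fluorine and 1 sulfur gives a 10-fold higher number from compound 3 to compound 4 (1.01 log units; beyond the scatter) as a large step beyond the scatter. Compound 1, compound 2 and compound 3 all lay within the scatter of one another, so none of them showed such a clear separation. No measurement here explains this loss of activity.

This change is seen only once, on a single pair of compounds. Going by these compounds, whether a chlorine atom or a methoxy group on this carbon would keep the activity of compound 3 or lose it as compound 4 does remains open.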